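Chloro analogue of compound 1: expected inhibition

A few compounds are considered here, and "the series" means these few. Any claim that something is new, unique, unknown or untested is made for them only; others in the source may bear on it.

Compound 1 `O=C(/C=C/c1ccccc1)c1ccc[nH]1` has no substituent on its six-membered aromatic ring of carbon only. In a functional assay on HL-60 cells (Homo sapiens) for inhibition, read by MTT assay, with a stated time of 48 h (on this read-out lower numbers stand for stronger inhibition and higher numbers for weaker inhibition), compound 1 reports only a limit of the assay, > 100000 nM. Two substituted analogues have been measured. Compound 2 `COc1cccc(/C=C/C(=O)c2ccc[nH]2)c1` gives 16000 nM in this assay. Compound 3 `O=C(/C=C/c1ccccc1Br)c1ccc[nH]1` gives 42000 nM in this assay. The step of an at least 6.2-fold lower number from compound 1 to compound 2 (0.79 log units; beyond the scatter) and the step of an at least 2.3-fold lower number from compound 1 to compound 3 (0.37 log units; beyond the scatter) both run toward lower numbers; their sizes are lower bounds only, because compound 1 sits at the limit of > 100000 nM in this assay, at which 1 of the 3 values shown sits.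

Compound 4 `O=C(/C=C/c1ccc(Cl)cc1)c1ccc[nH]1` is not yet measured. It differs from compound 1 by chloro in place of hydrogen on an aromatic carbon of a six-membered aromatic ring of carbon only, para to a group of 9 heavy atoms. Both measured steps from compound 1 place a single group on that ring and both give lower numbers beyond the scatter; the bromo step, a halogen like chloro, is the nearer comparison. A step in the same direction is therefore expected for compound 4, the step of an at least 3.3-fold lower number from compound 1 to compound 4 (0.52 log units; beyond the scatter) estimated toward a lower number. For compound 4 the estimate in this assay is 30000 nM, range 8000 nM to 100000 nM, with a real chance that only a limit is reported again.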

Compound 4, half-maximal inhibitory concentration: 13000 nM
Estimate against measurement, compound 4: 2.3-fold (0.36 log units) above; the range from low to high includes it.
By their numbers in this assay, from the lowest: compounds 4 and 2 (each within the scatter of the next); then compound 3. At a limit, above all of these: compound 1.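

In this assay, the step of an at least 7.6-fold lower number from compound 1 to compound 4 (0.88 log units; beyond the scatter) shows that a single chloro group on an aromatic carbon, para to a group of 9 heavy atoms, also brings the shared core to a measured value; neither compound 2 nor compound 3 carries its group at this place on the ring. With this step, all three single-group changes from compound 1 (methoxy, bromo and chloro) run toward lower numbers, and none of the compounds shown goes against that direction. The true size of the chloro step remains unknown, and it can be read only as a lower bound, because compound 1 stands at a limit: the limit of > 100000 nM in this assay, at which 1 of the 4 values shown sits.

The compounds shown leave open how much of the step belongs to chloro itself and how much to its place, since no group appears at more than one place on the ring. They also leave open whether a different kind of group at this same place, such as an amine or a carboxylic acid, would move the number in the same direction.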